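Working notes: the step from compound 3 to compound 4

A few compounds are considered here, and "the series" means these few. Any claim that something is new, unique, unknown or untested is made for them only; others in the source may bear on it.

Values in a functional assay on HL-60 cells (Homo sapiens) for inhibition, read by CCK-8 assay, with a stated time of 48 h (a lower number here means a stronger inhibitor, a higher number a weaker inhibitor), for the series so far:
- compound 1 `O=[N+]([O-])c1ccc(NC(=S)NCCNS(=O)(=O)c2ccc(-c3ccccc3O[C@H]3CC[C@@H](O)CC3)s2)cc1` gives > 50000 nM as a limit
- compound 2 `COc1cccc(NC(=O)NCCNS(=O)(=O)c2ccc(-c3ccccc3OCc3ccccc3)s2)c1` gives 1700 nM as a number
- compound 3 `O=[N+]([O-])c1ccc(NC(=S)NCCNS(=O)(=O)c2ccc(-c3ccccc3OCc3ccccc3)s2)cc1` gives > 50000 nM as a limit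

Compound 3 stands only at the limit of > 50000 nM in this assay, at which 2 of the 3 values shown sit, and gives no number. Compound 4 `Cc1cc(C)cc(NC(=O)NCCNS(=O)(=O)c2ccc(-c3ccccc3OCc3ccccc3)s2)c1` keeps the core of compound 3 and takes (3,5-dimethylphenyl)carbamoyl on an amine nitrogen, the change being a group of 11 heavy atoms (9 carbon, 1 nitrogen, 1 oxygen; one six-membered aromatic ring of carbon only) in place of a group of 12 heavy atoms (7 carbon, 2 nitrogen, 2 oxygen, 1 sulfur; one six-membered aromatic ring of carbon only), on an amine nitrogen and nothing else. The measured step that bears most directly is an at least 29-fold higher number from compound 2 to compound 3 (1.46 log units; beyond the scatter) and it is large. The other step, a step that the two limits leave unreadable from compound 1 to compound 3, concerns a different place and gives no size. Compound 4 resembles compound 2 in having a carbonyl in this group, though its aromatic ring is substituted differently. A large move toward a lower number in this assay is therefore expected, on the strength of compound 2 at 1700 nM as the nearest measured neighbour. The step expected is an at least 25-fold lower number from compound 3 to compound 4 (1.39 log units; beyond the scatter) by estimate. For compound 4 the estimated value is 2000 nM with an expected range from 600 nM to 8000 nM in this estimate.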

Compound 4, half-maximal inhibitory concentration: 2200 nM
The estimate for compound 4 lay 1.1-fold (0.04 log units) below the measured number; the range from low to high includes it.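

In this assay, a second group on this amine nitrogen, (3,5-dimethylphenyl)carbamoyl, gives an at least 22-fold lower number from compound 3 to compound 4 (1.35 log units; beyond the scatter) and shows that the move seen with compound 2 is not confined to a single group. With 3,5-dimethylphenyl in place of 3-methoxyphenyl on an amide-type nitrogen, the pair shows a 1.3-fold higher number from compound 2 to compound 4 (0.11 log units; within the scatter) and these two aromatic groups cannot be told apart in this assay.

Going by these compounds, whether the sulfur or the ring substitution of the group in compound 3 carries the step stays open, as does the outcome with an amine or a carboxylic acid on the aromatic ring of this group. The full size of the step also stays open, as compound 3 gives a limit and not a number: the limit of > 50000 nM in this assay, at which 2 of the 4 values shown sit.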